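Series notes: deoxy sugar variant of the thio analogue

A few compounds are considered here, and "the series" means these few. Any claim that something is new, unique, unknown or untested is made for them only; others in the source may bear on it.

In an assay on isolated protein for inhibition of DNA topoisomerase 1 (Homo sapiens), with a stated time of 30 min, tested at 100 uM (a lower number here means less inhibition, a higher number more inhibition at the concentration tested (going by the name of the read-out)), compound 1 `C[C@@H]1O[C@@H](OCC#Cc2c(-c3ccccc3)sc3ccccc23)C[C@H](N)[C@H]1O` gives 32.2%. Within the three measured compounds this places compound 1 second highest. Compound 2 `C[C@@H]1O[C@@H](OCC#Cc2c(-c3ccccc3)oc3ccccc23)C[C@H](N)[C@@H]1O`, in this assay, gives 77.8%, a number well above that of compound 1 and beyond the scatter. Compound 3 `C[C@@H]1O[C@@H](OCC#Cc2c(-c3ccccc3)[nH]c3ccccc23)C[C@H](N)[C@@H]1O` gives 8.8% in this assay, a number below that of compound 1, again beyond the scatter. Among the compounds with values here, compounds 2 and 3 differ from compound 1 in more than one place, so no single step between them is computed here; only their values can be set side by side.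

Compound 4 `C[C@@H]1O[C@@H](OCC#Cc2c(-c3ccccc3)sc3ccccc23)CC[C@@H]1N` has not been measured in this assay. Compared with compound 1 it differs as follows: a group of 8 heavy atoms (6 carbon, 1 nitrogen, 1 oxygen; one six-membered non-aromatic ring with 1 hetero atom) in place of a group of 9 heavy atoms (6 carbon, 1 nitrogen, 2 oxygen; one six-membered non-aromatic ring with 1 hetero atom), on an oxygen on a saturated carbon. The group that enters carries one hydrogen-bond donor and two acceptors where the group that leaves carried two donors and three acceptors, all else on the core of compound 1 being kept.

Within the data shown here, no measured pair shows this change, so its effect is unknown. Because compound 1 sits at 32.2%, a modest fall is expected rather than a rise, with the step from compound 1 to compound 4 estimated at a number 8.2 percentage points lower from compound 1 to compound 4 (within the scatter), which may not exceed the scatter. Compound 4 is estimated at 24% in this assay, within 5% to 48%.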

Compound 4, a percentage reported as inhibition, at one concentration (the size of the read-out at that concentration, not a potency): 7.9%
For compound 4 the middle estimate is 16.1 percentage points above the measured one; measured number inside the range.
By their numbers in this assay, from the lowest: compounds 4 and 3 (each within the scatter of the next); then compound 1; then compound 2.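

Within the data shown here, the group on the oxygen on a saturated carbon is the first place where a single change can be read: in this assay, the 5-amino-6-methyloxan-2-yl group gives a number 24.3 percentage points lower from compound 1 to compound 4 (beyond the scatter). Inhibition at the concentration tested therefore depends on the make-up of this group, which now carries one hydrogen-bond donor and two acceptors where the group it replaces carried two donors and three acceptors; the swap involves the whole group, however, so the contribution of any one part of it cannot be separated. Nothing available explains the fall in inhibition.

Among these compounds, whether the same swap has a comparable effect on the cores of compound 2 and compound 3 remains open, as the series offers only this one pair. Also open, going by these compounds, is how the read-out would respond to a dimethylamino group in place of the amino group on the 5-amino-6-methyloxan-2-yl group, or to a hydroxyl group in its place.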